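This account rests on a few compounds, and the source may have more. Where it says the series, first, only, none or still open, it means among the compounds named here.

Measured compounds:
Compound 1, `O=C(Nc1cccc(-n2cc(-c3ccncc3)c(-c3ccc(Cl)c(O)c3)n2)c1)Nc1cccc(C(F)(F)F)c1`, in a functional assay on U-251 cells (Homo sapiens) for inhibition, read by sulforhodamine B assay, with a stated time of 48 h (on this read-out lower numbers stand for higher toxicity in this test and higher numbers for lower toxicity in this test), gives only a limit of the test, > 32500 nM.
Compound 2, `COc1cc(-c2nn(-c3cccc(NC(=O)Nc4cc(C(F)(F)F)cc(C(F)(F)F)c4)c3)cc2-c2ccncc2)ccc1Cl`, in this assay gives 3180 nM.
Compound 3, `COc1cc(-c2nn(-c3cccc(NC(=O)Nc4cccc(C(F)(F)F)c4)c3)cc2-c2ccncc2)ccc1Cl`, in this assay gives 2920 nM.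

Of the three compounds, only compound 2 and compound 3 give numbers, and these two cannot be told apart: a 1.1-fold lower number from compound 2 to compound 3 (0.04 log units; within the scatter). Compound 1 stands apart, as it gives only a limit (the limit of > 32500 nM in this assay, at which 1 of the 3 values shown sits), and an at least 11-fold lower number from compound 1 to compound 3 (1.04 log units; beyond the scatter).

Compound 4, `COc1cc(-c2nn(-c3cccc(NC(=O)Nc4ccc(Cl)c(C(F)(F)F)c4)c3)cc2-c2ccncc2)ccc1Cl`, differs from compound 3 in one place: chloro in place of hydrogen on an aromatic carbon. Among the compounds with values here, the step that bears on this is the one from compound 2 to compound 3, which also changed a substituent on that same aromatic ring of the urea and stayed within the scatter. The step from compound 1 to compound 3 concerns the other end of the molecule and says nothing about this ring. A change on this ring is therefore expected to leave the number about where it is, with no step beyond the scatter: a 1.0-fold lower number from compound 3 to compound 4 (0.02 log units; within the scatter). For compound 4 in this assay the estimate is 2800 nM, between 1100 nM and 7500 nM.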

Compound 4, concentration lethal to 50% of the cells: 24700 nM
Compound 4: middle estimate off by 8.8-fold (0.95 log units), on the low side; measured number outside the range, above it.
By their numbers in this assay, from the lowest: compounds 3 and 2 (each within the scatter of the next); then compound 4. At a limit, above all of these: compound 1.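

In this assay, a single chlorine atom added to the 3-(trifluoromethyl)phenyl ring, ortho to the trifluoromethyl group and para to a large group, gives an 8.5-fold higher number from compound 3 to compound 4 (0.93 log units; beyond the scatter) and so means lower toxicity in this test. The earlier change on this same ring, a 1.1-fold lower number from compound 2 to compound 3 (0.04 log units; within the scatter), stayed within the scatter, so this ring is not indifferent to every change made on it: here, one added atom at this place is enough to move the number beyond the scatter. Nothing measured in this set gives a reason for the step.

As far as these compounds go, whether the rise belongs to chloro alone remains open, since a fluoro atom, a methyl group, a methoxy group or an amine at this place could behave differently. From the compounds shown here alone, it is also open whether the same chloro would have a similar effect on a core carrying a free hydroxyl group.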